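This account rests on a few compounds, and the source may have more. Where it says the series, first, only, none or still open, it means among the compounds named here.

Measured compounds:
compound 1, `Cc1cccc2sc(NC(=O)CCN3CCN(CC4CCCO4)CC3)nc12`, giving 109 nM in an assay on membranes from brain for displacement of a labelled ligand from Sigma non-opioid intracellular receptor 1 (Cavia porcellus), read by scintillation counting, with a stated time of 120 min; a higher number here means a weaker inhibitor, a lower number a stronger inhibitor
compound 2, `Cc1cccc2sc(NC(=O)CCN3CCN(CCN(C(C)C)C(C)C)CC3)nc12`, giving 809 nM in this assay

Compound 2 stands highest of the two numbers in this assay; its nearest neighbour is compound 1, and the step of a 7.4-fold higher number from compound 1 to compound 2 (0.87 log units; beyond the scatter) sets them apart by more than the scatter. Compound 3 is `Cc1cccc2sc(NC(=O)CCN3CCN(c4ccncc4)CC3)nc12`, not yet measured in this assay. It differs from compound 2 by pyridin-4-yl in place of 2-(diisopropylamino)ethyl on an amine nitrogen in a ring. Among the measured compounds shown here, only one measured step touches the same place, the step of a 7.4-fold higher number from compound 1 to compound 2 (0.87 log units; beyond the scatter), in which one group on that ring nitrogen was exchanged for another; it shows that an exchange at this position has moved the number well beyond the scatter. For the measured compounds named here, no measured pair, however, carries a pyridin-4-yl or any aromatic ring on that nitrogen, so the direction for compound 3 is not settled by the data. Since compound 2 holds the higher of the two numbers, the writer expects the exchange to bring the value back toward that of compound 1 rather than raise it further, and therefore expects a step of a 2.7-fold lower number from compound 2 to compound 3 (0.43 log units; beyond the scatter). For compound 3 the expected value in this assay is 300 nM, with a range from 60 nM to 1500 nM.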

Compound 3, inhibition constant: 9600 nM
Compound 3: the middle estimate sits 32-fold (1.51 log units) below what was measured, outside the stated range (above it).
By their numbers in this assay, from the lowest: compound 1; then compound 2; then compound 3.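

In this assay, the exchange at the amine nitrogen of the six-membered ring did not bring the number back down: a 12-fold higher number from compound 2 to compound 3 (1.07 log units; beyond the scatter) with pyridin-4-yl in place of 2-(diisopropylamino)ethyl, and an 88-fold higher number from compound 1 to compound 3 (1.94 log units; beyond the scatter) with pyridin-4-yl in place of (oxolan-2-yl)methyl. Both steps are larger than the earlier 7.4-fold higher number from compound 1 to compound 2 (0.87 log units; beyond the scatter), so among these three compounds, the choice between the two saturated-chain groups matters less than the exchange of either one for the aromatic ring, and no compound shown goes against this. Among the compounds shown here, nothing available here explains why pyridin-4-yl raises the number so far.

With a single aromatic group at this position, the compounds shown leave open whether the high number belongs to aromatic rings on this nitrogen in general or to pyridin-4-yl in particular, which a phenyl ring would help to separate. They also leave open whether a benzyl group, which places a saturated carbon between that nitrogen and an aromatic ring, would stay near the number of compound 3 or move toward those of compound 1 and compound 2.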